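This account rests on a few compounds, and the source may have more. Where it says the series, first, only, none or still open, it means among the compounds named here.

Of the compounds shown here, three built on a shared core have been measured in a functional assay on HeLa cells (Homo sapiens) for cytotoxicity, read by MTT assay, with a stated time of 72 h; on this read-out lower numbers stand for stronger inhibition and higher numbers for weaker inhibition. Compound 1 `Cn1ccc2c(Oc3ccc(NC(=O)c4cc5cccnc5n(-c5ccc(Br)cc5)c4=O)cc3F)ncnc21` gives 33800 nM, compound 2 `O=C(Nc1ccc(Oc2ncnc3[nH]ccc23)c(F)c1)c1cc2cccnc2n(-c2ccc(F)cc2)c1=O` gives 3720 nM, and compound 3 `O=C(Nc1ccc(Oc2ncnc3[nH]ccc23)c(F)c1)c1cc2cccnc2n(-c2ccc(Cl)cc2)c1=O` gives 23900 nM. Compound 3 therefore lies within the scatter of compound 1, while its number is clearly higher than that of compound 2.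

Compound 4 `O=C(Nc1ccc(Oc2ncnc3[nH]ccc23)c(F)c1)c1cc2cccnc2n(-c2ccc(Br)cc2)c1=O` has not yet been measured. It differs from compound 3 in a single place bromo in place of chloro on an aromatic carbon, which turns 4-chlorophenyl into 4-bromophenyl.

Two pieces of evidence bear on this change. Among the measured compounds shown here, the only measured step in this group is chloro in place of fluoro, a 6.4-fold higher number from compound 2 to compound 3 (0.81 log units; beyond the scatter), a modest change beyond the scatter. It shows that this group can matter, but a single step does not establish a trend. Although its core is not identical to that of compound 3, compound 1 already carries the 4-bromophenyl group and gives 33800 nM.

A small rise within the scatter is therefore expected in this assay, with the estimated step being a 1.1-fold higher number from compound 3 to compound 4 (0.05 log units; within the scatter). For compound 4, the estimated value is 27000 nM, with an expected range from 12000 nM to 55000 nM.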

Compound 4, half-maximal inhibitory concentration: 19900 nM
Beside the measured number, compound 4's estimate is 1.4-fold (0.13 log units) above it; measured number inside the range.
By their numbers in this assay, from the lowest: compound 2; then compounds 4, 3 and 1 (each within the scatter of the next).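

In this assay, bromo in place of chloro, on an aromatic carbon para to a large group, gives a step inside the scatter (a 1.2-fold lower number from compound 3 to compound 4 (0.08 log units; within the scatter)), so these two groups cannot be told apart here, while fluoro now stands clear of both, as the step to bromo (a 5.3-fold higher number from compound 2 to compound 4 (0.73 log units; beyond the scatter)) joins the earlier step to chloro (a 6.4-fold higher number from compound 2 to compound 3 (0.81 log units; beyond the scatter)). Among the compounds shown here, compound 1 and compound 4 differ only in hydrogen in place of methyl on an aromatic nitrogen, and that step also lies within the scatter (a 1.7-fold lower number from compound 1 to compound 4 (0.23 log units; within the scatter)), which gives the first direct reading of this methyl group with the 4-bromophenyl group held fixed. No measurement shown here explains why fluoro differs from chloro and bromo.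

With only three groups shown at this position, it remains open whether fluoro is a special case or part of a wider pattern, which plain hydrogen, methoxy, a nitrile or an amine in the same place could help to settle. Going by these compounds, it is also open whether the methyl group on the aromatic nitrogen would read the same with fluoro in place of bromo.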